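Phenylsulfanyl in Place of the Sulfonyl Group on the Anilide

A few compounds are considered here, and "the series" means these few. Any claim that something is new, unique, unknown or untested is made for them only; others in the source may bear on it.

compound 1, `CC(O)(C(=O)Nc1ccc(S(=O)(=O)N2CCCC2)cc1)C(F)(F)F`: 880 nM
compound 2, `CCN(CC)C(=O)c1ccc(NC(=O)C(C)(O)C(F)(F)F)cc1`: > 30000 nM (a limit)
compound 3, `CC(O)(C(=O)Nc1ccc(/C(=N\O)c2ccccc2)cc1)C(F)(F)F`: > 30000 nM (a limit)

In an assay on a protein complex (Cavia porcellus) with sulfonylurea receptors; K-ATP channels (Homo sapiens) as the target (a higher number here means a weaker inhibitor, a lower number a stronger inhibitor), compound 1 gives 880 nM. For compound 2 this assay reports only a limit, > 30000 nM. For compound 3 it likewise reports only a limit, > 30000 nM. Compound 1 therefore holds the only number shown, the other two values sitting at the limit of > 30000 nM in this assay, at which 2 of the 3 values shown sit. Compound 4, `CC(O)(C(=O)Nc1ccc(Sc2ccccc2)cc1)C(F)(F)F`, differs from compound 1 in one place: phenylsulfanyl in place of (pyrrolidin-1-yl)sulfonyl on an aromatic carbon. For the measured compounds named here, the one measured step at this place is an at least 34-fold higher number from compound 1 to compound 2 (1.53 log units; beyond the scatter), a large loss once the (pyrrolidin-1-yl)sulfonyl is exchanged. That step bears directly on the present one, so a clearly weaker inhibitor is expected. Compound 4 is estimated at 8000 nM, within 1500 nM to 40000 nM. The expected step is a 9.1-fold higher number from compound 1 to compound 4 (0.96 log units; beyond the scatter).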

Compound 4, half-maximal inhibitory concentration: > 30000 nM
Compound 4 ended at the assay's limit; the forecaster's own chance of this, stated with the estimate: 35%; at least 3.7-fold (0.57 log units) between middle value and limit.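

In this assay, replacing (pyrrolidin-1-yl)sulfonyl with phenylsulfanyl gives an at least 34-fold higher number from compound 1 to compound 4 (1.53 log units; beyond the scatter), and this step rests on a limit for compound 4, not on a number. Together with compound 2, this is a second replacement at this place that ends at the limit, so the loss is not peculiar to diethylcarbamoyl. The step from compound 2 to compound 4 cannot be read: the limit of > 30000 nM in this assay, at which 3 of the 4 values shown sit.

On these data alone, it remains open whether the sulfonyl or the five-membered non-aromatic ring carries the activity of compound 1. A methylsulfonyl or phenylsulfonyl group at this place could separate the two.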